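From compound 2 to compound 3: an aryl swap

The source may hold more compounds than are shown below. What is called first, only, known or untested is meant among the compounds shown, and "the series" means these compounds.

Measured so far in a functional assay on B16-F0 cells (Mus musculus) for inhibition, read by CCK-8 assay, with a stated time of 48 h; on this read-out higher numbers stand for weaker inhibition and lower numbers for stronger inhibition:
- compound 1 `COc1cc(-c2ccnc3cc(-c4ccc(N(C)C)cc4)nn23)cc(OC)c1OC` gives 702 nM
- compound 2 `COc1cc(-c2ccnc3cc(-c4cccc(C)c4)nn23)cc(OC)c1OC` gives 2220 nM

Of the two numbers in this assay, compound 2 holds the higher, so it is the weaker inhibitor of the pair. The next structure is compound 3 `COc1cc(-c2ccnc3cc(-c4ccc5ccn(C)c5c4)nn23)cc(OC)c1OC`, with 1-methyl-1H-indol-6-yl in place of 3-methylphenyl on an aromatic carbon. Among the measured compounds shown here, only one measured step bears on this change, a 3.2-fold higher number from compound 1 to compound 2 (0.50 log units; beyond the scatter), which is modest but beyond the scatter. It shows that exchanging the group at this place can move the number in this assay. For the measured compounds named here, no measured compound carries 1-methyl-1H-indol-6-yl, so the direction is tentative. It rests on compound 2 sitting at the higher end, with compound 1 lower at 702 nM and no data above compound 2. A step of similar modest size toward a lower number is therefore expected, namely a 6.3-fold lower number from compound 2 to compound 3 (0.80 log units; beyond the scatter) as the estimated move. For compound 3 the estimated value is 350 nM (expected range 50 nM to 2000 nM).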

Compound 3, half-maximal inhibitory concentration: 657 nM
Compound 3: middle estimate off by 1.9-fold (0.27 log units), on the low side; the range from low to high includes it.
By their numbers in this assay, from the lowest: compounds 3 and 1 (each within the scatter of the next); then compound 2.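

Notes on the aromatic carbon of the five-membered ring with two nitrogens: in this assay, the two-ring 1-methyl-1H-indol-6-yl group replaces the single-ring 3-methylphenyl group with a 3.4-fold lower number from compound 2 to compound 3 (0.53 log units; beyond the scatter), so this position accepts a larger fused aryl group without loss and the number moves beyond the scatter. Against the other single-ring aryl group the change gives a 1.1-fold lower number from compound 1 to compound 3 (0.03 log units; within the scatter), so 1-methyl-1H-indol-6-yl and 4-(dimethylamino)phenyl cannot be told apart here, even though they differ in ring makeup; among these three compounds, the two groups carrying a nitrogen sit together, and the carbon-only 3-methylphenyl group of compound 2 stands apart. No measured property of these groups bears on the step, so what drives it stays unassigned.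

The compounds shown leave open whether the methyl on the indole nitrogen matters, which the unmethylated 1H-indol-6-yl group would test. Also open, from the compounds shown here alone, is whether a nitrogen is needed at all, which a naphthyl group would address, and whether a morpholine or a carboxylic acid on the phenyl ring would hold the number at the level shared by compound 1 and compound 3.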